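The source may hold more compounds than are shown below. What is called first, only, known or untested is meant among the compounds shown, and "the series" means these compounds.

In an ADME assay on HepG2 cells (Homo sapiens) for cytotoxicity (a higher number here means that more compound is tolerated, a lower number that less compound is tolerated), compound 1 (`NC(=O)c1cccc(NC(=O)C2CN(c3ccccc3)CC(=O)N2c2ccc3ccsc3c2)c1`) gives > 50000 nM, a limit of the assay. Compound 2 (`N#Cc1cccc(NC(=O)C2CN(c3ccccc3)CC(=O)N2c2ccc3ccsc3c2)c1`) gives > 50000 nM, again only a limit, so its position is not a number. Going by the values given here, the series so far stands at the limit of > 50000 nM in this assay, at which 2 of the 2 values shown sit. Among the compounds with values here, the one measured step is a step that the two limits leave unreadable from compound 1 to compound 2, and it offers no size to carry forward. Compound 3 (`O=C(Nc1cccnc1)C1CN(c2ccccc2)CC(=O)N1c1ccc2ccsc2c1`) differs from compound 2 as follows: pyridin-3-yl in place of 3-cyanophenyl on an amide-type nitrogen. Within the data shown here, no measured step covers this change, so no shift beyond the scatter is expected in this assay. The expected step is a number no higher from compound 2 to compound 3 (the limit leaves the size open). Compound 3 is estimated at 50000 nM, with an expected range from 25000 nM to 50000 nM.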

Compound 3, half-maximal cytotoxic concentration: > 50000 nM
Compound 3: no number, only a limit; the forecaster's own chance of this, stated with the estimate: 85%; the middle value sits exactly at the limit.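

No step among compound 1, compound 2 and compound 3 can be read in this assay: the limit of > 50000 nM in this assay, at which 3 of the 3 values shown sit.

The compounds shown leave open the actual tolerated concentration of each, and so whether the changes between them shift this assay at all.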